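This account rests on a few compounds, and the source may have more. Where it says the series, first, only, none or still open, it means among the compounds named here.

Measured compounds:
Compound 1 `COc1cccc(OC)c1OCCNCCOc1ccccc1OCc1cccc(Cl)c1`: 5900 nM
Compound 2 `COc1cccc(OC)c1OCCNCCOc1ccccc1OCc1ccc(C)cc1`: 7800 nM
Compound 3 `COc1ccc(COc2ccccc2OCCNCCOc2c(OC)cccc2OC)cc1`: 8500 nM

In a functional assay on PC-3 cells (Homo sapiens) for cytotoxicity, read by sulforhodamine B assay (on this read-out lower numbers stand for stronger inhibition of growth and higher numbers for weaker inhibition of growth), compound 1 has the lowest of the three numbers, but its steps to compound 2 and to compound 3 both lie within the scatter, so none of the three can be called more or less active than the others. Compound 4 `CCOc1ccc(COc2ccccc2OCCNCCOc2c(OC)cccc2OC)cc1` differs from compound 1 in one place: 4-ethoxyphenyl in place of 3-chlorophenyl on a saturated chain carbon bound to an oxygen on an aromatic ring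

For the measured compounds named here, two measured steps bear on this change, since each also swaps the 3-chlorophenyl of compound 1 for a phenyl ring carrying a single group in the 4-position: a 1.3-fold higher number from compound 1 to compound 2 (0.12 log units; within the scatter) and a 1.4-fold higher number from compound 1 to compound 3 (0.16 log units; within the scatter). Both are within the scatter. The third step, a 1.1-fold higher number from compound 2 to compound 3 (0.04 log units; within the scatter), shows that exchanging methoxy for methyl on that ring also changes nothing beyond the scatter. The 4-ethoxyphenyl entering compound 4 resembles the 4-methoxyphenyl of compound 3 most closely, so a small rise in the number, at most like that from compound 1 to compound 3, is expected. The expected step, a 1.4-fold higher number from compound 1 to compound 4 (0.16 log units; within the scatter), is estimated to stay within the scatter. Compound 4 is therefore expected to give 8500 nM, with a likely range from 4500 nM to 16000 nM.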

Compound 4, concentration for 50% growth inhibition: 5200 nM
Compound 4: the middle estimate sits 1.6-fold (0.21 log units) above what was measured, and the stated range covers the measured number.
By their numbers in this assay, from the lowest: compounds 4, 1, 2 and 3 (each within the scatter of the next).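

Putting 4-ethoxyphenyl in place of 3-chlorophenyl on this saturated chain carbon gives a 1.1-fold lower number from compound 1 to compound 4 (0.05 log units; within the scatter) in this assay, so this exchange leaves the read-out within its usual scatter. The earlier compounds carried only methyl or methoxy on the phenyl ring, and the new compound extends that series to ethoxy: going from methoxy to ethoxy gives a 1.6-fold lower number from compound 3 to compound 4 (0.21 log units; within the scatter), and going from methyl to ethoxy gives a 1.5-fold lower number from compound 2 to compound 4 (0.18 log units; within the scatter), so neither step can be read as a real change and all four phenyl groups shown are indistinguishable here. No independent measurement is available to explain this flat result.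

On these data alone, what remains open is whether any group on this phenyl ring can move the number beyond the scatter, for instance an amine, a carboxylic acid or a longer chain such as butoxy in place of the ethoxy. Also open is what 4-chlorophenyl would give, since that group would allow the chlorine itself to be compared directly with the 4-substituted rings shown here.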